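Working notes: furan-2-yl to phenyl, compound 3

This account rests on a few compounds, and the source may have more. Where it says the series, first, only, none or still open, it means among the compounds named here.

Measured so far:
compound 1 `Oc1cccc(-c2cc(-c3ccc(Cl)cc3)nc(-c3ccco3)c2)c1`: 10200 nM
compound 2 `Oc1cccc(-c2cc(-c3cccc(Cl)c3)nc(-c3ccco3)c2)c1`: 2460 nM

In a functional assay on HCT-15 cells (Homo sapiens) for cytotoxicity, read by CCK-8 assay and cell counting, with a stated time of 2 days (a lower number here means a stronger inhibitor, a higher number a weaker inhibitor), compound 1 gives 10200 nM, the highest of the two numbers recorded; its nearest neighbour is compound 2, and the step of a 4.1-fold lower number from compound 1 to compound 2 (0.62 log units; beyond the scatter) is the only one in hand. That step exchanges 3-chlorophenyl for 4-chlorophenyl on an aromatic carbon of the shared core and says nothing about the other aryl group.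

Compound 3 `Oc1cccc(-c2cc(-c3ccccc3)nc(-c3ccc(Cl)cc3)c2)c1` is unmeasured. It differs from compound 1 by phenyl in place of furan-2-yl on an aromatic carbon. Going by the values given here, no measured pair changes the furan-2-yl group, so the shared core offers no guide to the size or the direction of this change. Without a bearing step the working assumption is no movement beyond the scatter in this assay, with wide uncertainty on either side. Compound 3 is therefore expected to give about 10000 nM, between 3000 nM and 35000 nM, which is the estimated step of a 1.0-fold lower number from compound 1 to compound 3 (0.01 log units; within the scatter).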

Compound 3, half-maximal inhibitory concentration: 8110 nM
Compound 3: the middle estimate sits 1.2-fold (0.09 log units) above what was measured, and the stated range covers the measured number.
By their numbers in this assay, from the lowest: compound 2; then compounds 3 and 1 (each within the scatter of the next).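

In this assay, phenyl in place of furan-2-yl on the aromatic carbon next to the ring nitrogen gives a 1.3-fold lower number from compound 1 to compound 3 (0.10 log units; within the scatter), so this pair cannot be told apart at this read-out. Going by these compounds alone, this is the first reading at this position, and it shows that, with a 4-chlorophenyl group on the shared core, the five-membered ring with its oxygen and the all-carbon six-membered ring are interchangeable within the scatter, whereas the chlorine shift gave a 4.1-fold lower number from compound 1 to compound 2 (0.62 log units; beyond the scatter), a step beyond it. No measurement bears on why the two aryl groups read alike in this pair.

Within the data shown here, with only one pair at this position, it remains open whether the position tolerates groups of a different kind, such as an amine, a carboxylic acid or a longer alkyl chain in place of the aromatic ring. Also open, from the compounds shown here alone, is whether the same replacement reads alike on the core carrying the 3-chlorophenyl group, and whether the step for the chlorine shift persists when phenyl stands in place of furan-2-yl.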